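Swapping the Amide Aryl Group and Expected Cytotoxicity

The compounds below may be only part of what the source reports. "The series", "measured", "known", "first", "only" and "open" are said of these compounds alone.

Three amides built on one shared core have been tested in an ADME assay on HepG2 2.2.15 cells (Homo sapiens) for cytotoxicity, read by MTT assay, with stated times of 48 h and 9 days; on this read-out higher numbers stand for lower toxicity in this test and lower numbers for higher toxicity in this test. Compound 1 `COc1ccc(CNC(=O)/C=C/c2coc3cc(OC)ccc3c2=O)cc1` gives 43000 nM. Compound 2 `COc1ccc2c(=O)c(/C=C/C(=O)NCc3ccc(C)cc3)coc2c1` gives 257000 nM in this assay, and compound 3 `COc1ccc(NC(=O)/C=C/c2coc3cc(OC)ccc3c2=O)cc1` gives 718000 nM. Compound 3 therefore stands highest of the three, meaning least toxic here, and its separation from the others, a 2.8-fold higher number from compound 2 to compound 3 (0.45 log units; beyond the scatter) and a 17-fold higher number from compound 1 to compound 3 (1.22 log units; beyond the scatter), lies beyond the scatter in both cases. Compound 4 `COc1ccc2c(=O)c(/C=C/C(=O)Nc3ccccc3C)coc2c1` differs from compound 3 in one place: 2-methylphenyl in place of 4-methoxyphenyl on an amide-type nitrogen. For the measured compounds named here, two measured steps bear on this. The step of a 6.0-fold higher number from compound 1 to compound 2 (0.78 log units; beyond the scatter) shows that trading methoxy for methyl raised the number, while a 2.8-fold higher number from compound 2 to compound 3 (0.45 log units; beyond the scatter) shows that a phenyl group on the nitrogen in place of a benzyl group raised it further. Compound 4 keeps the phenyl attachment and trades methoxy for methyl, so a small rise or no step beyond the scatter is expected, a 1.2-fold higher number from compound 3 to compound 4 (0.07 log units; within the scatter). Compound 4 is thus estimated at 850000 nM, with a range from 250000 nM to 2500000 nM.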

Compound 4, half-maximal cytotoxic concentration: 59700 nM
Estimate against measurement, compound 4: 14-fold (1.15 log units) above; the whole stated range lies above it.
By their numbers in this assay, from the lowest: compounds 1 and 4 (each within the scatter of the next); then compound 2; then compound 3.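

For the compounds shown here, on the amide-type nitrogen, the choice of aryl group matters more than the earlier compounds could show: in this assay, 2-methylphenyl in place of 4-methoxyphenyl gives a 12-fold lower number from compound 3 to compound 4 (1.08 log units; beyond the scatter) and so takes away most of what made compound 3 stand out. An aryl ring directly on the nitrogen therefore does not by itself raise the number, as the comparisons with the benzyl amides confirm: there is a 4.3-fold lower number from compound 2 to compound 4 (0.63 log units; beyond the scatter) and, within the scatter, a 1.4-fold higher number from compound 1 to compound 4 (0.14 log units; within the scatter) as well. Nothing measured here accounts for this drop.

As far as these compounds go, whether the step comes from the methyl group or from its place on the ring stays open, and a 4-methylphenyl group on the same nitrogen would separate the two. From the compounds shown here alone, how a phenyl ring carrying an amine or a carboxylic acid would behave at this position is equally open.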